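The source may hold more compounds than are shown below. What is called first, only, known or untested is meant among the compounds shown, and "the series" means these compounds.

Measured compounds:
- compound 1 `NCCCCc1c[nH]c2ccc(C(=O)O)cc12`: "not active" (no number reported) in an assay on isolated protein (urine) for inhibition of Myeloperoxidase (Homo sapiens), with a stated time of 5 min; on this read-out lower numbers stand for stronger inhibition and higher numbers for weaker inhibition
- compound 2 `NCC(N)CCc1c[nH]c2ccc(F)cc12`: 60 nM
- compound 3 `ONCCCc1c[nH]c2ccc(F)cc12`: 11 nM

Compound 1 stands apart: in this assay it gave no number, only the report that compound 1 is "not active" (no number reported), so it has no place among the numbers of compound 2 and compound 3.

Compound 4 `NCCCc1c[nH]c2ccc(C(=O)O)cc12` differs from compound 1 by amino in place of aminomethyl on a saturated chain carbon, three bonds along the chain from an aromatic carbon. Going by the values given here, the only measured step, a 5.5-fold lower number from compound 2 to compound 3 (0.74 log units; beyond the scatter), concerns a different change and does not bear on this one. Among the compounds with values here, no measured step tells what shortening this chain does, and compound 1 itself gives no number to start from. The expectation for compound 4 therefore rests on compound 1 alone and stays weak: an estimate of 10000 nM, with a range from 1000 nM to 100000 nM, and a real chance that again no number is reported.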

Compound 4, half-maximal inhibitory concentration: "not active" (no number reported)
Nothing numeric was reported for compound 4; no gap can be computed for the estimate.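

No step can be read between compound 1 and compound 4: in this assay neither gives a number, and no supporting data bear on this result. Still open, as far as these compounds go, is whether any chain length on this core gives measurable inhibition.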